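The source may report more compounds than this note shows. Statements on the series, on what has been measured and on what is new or still open speak of the compounds shown alone.

Measured compounds:
- Compound 1, `COc1cc(-c2nnc3n2NC(c2ccco2)C(C(=O)c2ccccc2C)S3)cc(OC)c1OC`: in a functional assay on A549 cells (Homo sapiens) for cytotoxicity, read by MTT assay, with a stated time of 48 h (a higher number here means a weaker inhibitor, a lower number a stronger inhibitor), compound 1 gives 80000 nM.
- Compound 2, `COc1cc(-c2nnc3n2NC(c2ccco2)C(C(=O)c2ccc(Cl)cc2)S3)cc(OC)c1OC`: in this assay compound 2 gives 51400 nM.

Among the measured compounds shown here, compound 2 holds the lowest of the two numbers measured so far, but its only neighbour is compound 1, and the step of a 1.6-fold lower number from compound 1 to compound 2 (0.19 log units; within the scatter) lies within the scatter, so the two cannot be told apart on these data.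

Compound 3, `COc1cc(-c2nnc3n2NC(c2ccco2)C(C(=O)c2ccc(F)cc2)S3)cc(OC)c1OC`, keeps the shared core of compound 2 and changes only one atom: fluoro in place of chloro on an aromatic carbon. For the measured compounds named here, the sole measured step, that from compound 1 to compound 2, swapped a whole phenyl substituent pattern and still stayed within the scatter; no measured pair shows a fluoro against a chloro, so nothing here speaks for a shift beyond the scatter. A step of no more than the usual scatter is therefore expected from compound 2 to compound 3, a 1.2-fold higher number from compound 2 to compound 3 (0.07 log units; within the scatter). For compound 3 in this assay the estimate is 60000 nM, with a range from 30000 nM to 130000 nM.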

Compound 3, half-maximal inhibitory concentration: 53700 nM
Beside the measured number, compound 3's estimate is 1.1-fold (0.05 log units) above it; measured number inside the range.
By their numbers in this assay, from the lowest: compounds 2, 3 and 1 (each within the scatter of the next).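

In this assay, among the compounds shown here, replacing chloro with fluoro on an aromatic carbon, para to a large group, gives a 1.0-fold higher number from compound 2 to compound 3 (0.02 log units; within the scatter), which is the first direct comparison of these two atoms at this position and shows no difference that can be told from the scatter. The change from 2-methylphenyl to 4-fluorophenyl on the carbonyl carbon gives a 1.5-fold lower number from compound 1 to compound 3 (0.17 log units; within the scatter), so it also stays within the scatter, as does a 1.6-fold lower number from compound 1 to compound 2 (0.19 log units; within the scatter) for the change to 4-chlorophenyl; across these three compounds, then, the aromatic group on the carbonyl has not yet produced a step that can be read as real. Nothing available explains why the numbers lie so close together.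

Still open, as far as these compounds go, is whether a group of a different kind at this para position, such as an amine, a carboxylic acid or a longer chain, would move the number beyond the scatter. These compounds also leave open whether changes elsewhere on the shared core would have a larger effect than those seen on this aromatic group.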